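Swapping trifluoromethyl for bromo on a benzyl ether

The compounds below may be only part of what the source reports. "The series", "measured", "known", "first", "only" and "open" are said of these compounds alone.

Measured compounds:
- compound 1, `Brc1ccc(OCCOc2nc3ccccc3s2)cc1`: 94.6%
- compound 2, `Brc1cccc(COc2nc3ccccc3s2)c1`: 77.6%
- compound 3, `FC(F)(F)c1ccc(COc2nc3ccccc3s2)cc1`: 12.2%

In a functional assay on the whole organism with Mus musculus as the target, with a stated time of 1 h, at a dose of 100 mg/kg by the intraperitoneal route (a lower number here means less inhibition, a higher number more inhibition at the dose given (going by the name of the read-out)), compound 3 gives 12.2%, the lowest of the three numbers. Compound 2 gives 77.6%, and compound 1 gives 94.6%; both gaps to compound 3 lie beyond the scatter. Both of these compounds with the higher numbers carry bromo on their outer ring, while compound 3 carries trifluoromethyl there.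

Compound 4, `Brc1ccc(COc2nc3ccccc3s2)cc1`, has not yet been measured. Among the compounds with values here, its single change from compound 3 is bromo in place of trifluoromethyl on an aromatic carbon. Within the data shown here, with no measured pair showing exactly this swap, the expectation rests on the two bromo compounds: compound 2 gives 77.6% and compound 1 gives 94.6%, so a large rise in this assay is expected, far beyond the scatter. The estimated step from compound 3 to compound 4 in this assay is a number 57.8 percentage points higher from compound 3 to compound 4 (beyond the scatter). Compound 4 is therefore expected to give about 70%, within a range from 30% to 95%.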

Compound 4, a percentage reported as inhibition, in the whole organism at one dose (the size of the read-out at that dose, not a potency): 78%
Estimate against measurement, compound 4: 8 percentage points below; the range from low to high includes it.
By their numbers in this assay, from the lowest: compound 3; then compounds 2 and 4 (each within the scatter of the next); then compound 1.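

Within the data shown here, compounds 3 and 4 form the first pair that isolates this change: with the rest of the molecule the same, putting bromo in place of trifluoromethyl on an aromatic carbon, para to a large group, gives a number 65.8 percentage points higher from compound 3 to compound 4 (beyond the scatter) in this assay. The low number of compound 3 therefore goes with the trifluoromethyl group and not with the rest of its structure, which compound 4 shares. No measurement at hand explains why this single swap has so large an effect.

From the compounds shown here alone, it remains open whether an amine or a methoxy group at this place would give a number close to that of compound 3 or to that of compound 4. Also open, going by these compounds, is whether the same swap would give a step of similar size on the longer chain of compound 1.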